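Coumarin-bearing pyrazolines: from chloroacetyl to a piperidinyl amide

The source may report more compounds than this note shows. Statements on the series, on what has been measured and on what is new or still open speak of the compounds shown alone.

Compound 1 `CC1=NN(C(=O)c2ccc(C)cc2)C(c2cc(Br)cc(Br)c2O)C1`: "not active" (no number reported) in a functional assay on HepG2 cells (Homo sapiens) for cytotoxicity, read by MTT assay, with a stated time of 48 h; a lower number here means a stronger inhibitor, a higher number a weaker inhibitor
Compound 2 `O=C(CCl)N1N=C(c2cc3ccccc3oc2=O)CC1c1ccccc1`: 2980 nM

Compound 2 stands alone with a numerical result in this assay; compound 1 shows "not active" (no number reported) without a number. Compound 3 `CC1CCCN(CC(=O)N2N=C(c3cc4ccccc4oc3=O)CC2c2ccccc2)C1` is not yet measured. It differs from compound 2 by 3-methylpiperidin-1-yl in place of chloro on a saturated chain carbon bound to a carbonyl carbon. Among the measured compounds shown here, no step between measured compounds is on record for this kind of change, so the expectation rests on compound 2 alone. A moderate weakening beyond the scatter is expected, a 2.7-fold higher number from compound 2 to compound 3 (0.43 log units; beyond the scatter). Compound 3 is therefore estimated at 8000 nM, within a range from 2500 nM to 30000 nM.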

Compound 3, half-maximal inhibitory concentration: "not active" (no number reported)
Nothing numeric was reported for compound 3; no gap can be computed for the estimate.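

Among the compounds shown here, compound 3 carries no number, so no step from compound 2 to compound 3 can be read. The compounds shown leave open whether any other group in place of chloro keeps measurable activity in this assay. No measured evidence bears on this result.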